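Swapping a phenyl for a larger bicyclic group on a shared core

A few compounds are considered here, and "the series" means these few. Any claim that something is new, unique, unknown or untested is made for them only; others in the source may bear on it.

Compound 1 `c1ccc(-c2ccc(Cn3cncc3CNc3ccc(-c4ccccc4)c(-c4ccccc4)c3)cc2)cc1` carries two phenyl groups on its core. In a toxicity assay on NIH3T3 cells (Mus musculus) for cytotoxicity, read by resazurin assay (a higher number here means that more compound is needed for the effect, a lower number that less compound is needed), compound 1 gives > 10000 nM, which is a limit of the assay and not a number. Compound 3 `c1ccc(-c2ccc(Cn3cncc3CNc3ccc(-c4ccccc4)cc3)cc2)cc1` gives > 10000 nM in this assay, again only a limit. Compound 2 `CC(C)c1ccc(Cn2cncc2CNc2ccc(-c3nc4ccccc4s3)c(-c3ccccc3)c2)cc1` gives > 1000 nM, also a limit. Among the measured compounds shown here, the one step on record, a step that the two limits leave unreadable from compound 1 to compound 3, cannot be read, and the two limits the limit of > 10000 nM in this assay, at which 2 of the 3 values shown sit, and the limit of > 1000 nM in this assay, at which 1 of the 3 values shown sits, are all the evidence. Compound 4 `c1ccc(-c2ccc(Cn3cncc3CNc3ccc(-c4onc5ccccc45)c(-c4ccccc4)c3)cc2)cc1` differs from compound 1 by a group of 9 heavy atoms (7 carbon, 1 nitrogen, 1 oxygen; one five-membered aromatic ring with 2 hetero atoms, one six-membered aromatic ring of carbon only) in place of a group of 6 heavy atoms (6 carbon; one six-membered aromatic ring of carbon only), on an aromatic carbon. For the measured compounds named here, no measured step bears on this change, so no shift beyond the scatter is expected. Compound 4 is therefore estimated to give 15000 nM in this assay, between 4000 nM and 60000 nM, a change of a step that the limit leaves unreadable from compound 1 to compound 4 expected most likely to appear again as a limit.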

Compound 4, half-maximal effective concentration: > 10000 nM
Compound 4 was reported as a limit (the forecaster's own chance of this, stated with the estimate: 80%); the middle value lies beyond the limit too.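

The step from compound 1 to compound 4 cannot be read, as both compounds are reported only as limits in this assay. The compounds shown leave open how much of any of them produces the toxic effect on these cells.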